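Phenyl Replaces the Substituted Ring on the Amide Carbonyl

This account rests on a few compounds, and the source may have more. Where it says the series, first, only, none or still open, it means among the compounds named here.

The measured compounds so far:
Compound 1, `Cc1c(Cl)cccc1C(=O)NC(CCN(C)C)c1ccc(Cl)cc1`, gives 142% in an assay on NIH3T3 cells with Urotensin-2 receptor (Homo sapiens) as the target; a higher number here means a larger maximal response, a lower number a smaller maximal response.
Compound 2, `Cc1ccc(C)c(C(=O)NC(CCN(C)C)c2ccc(Cl)cc2)c1`, gives 164%.
Compound 3, `Cc1cccc(Cl)c1C(=O)NC(CCN(C)C)c1ccc(Cl)cc1`, gives 105%.

Compound 3 stands lowest of the three. Its nearest neighbour is compound 1, and the step of a number 37 percentage points lower from compound 1 to compound 3 (beyond the scatter); the furthest is compound 2, and the step of a number 59 percentage points lower from compound 2 to compound 3 (beyond the scatter). Compound 4, `CN(C)CCC(NC(=O)c1ccccc1)c1ccc(Cl)cc1`, has not yet been measured. It differs from compound 3 in one place: phenyl in place of 2-chloro-6-methylphenyl on a carbonyl carbon.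

For the measured compounds named here, two measured steps bear on this change, since both end at the 2-chloro-6-methylphenyl group of compound 3: a number 37 percentage points lower from compound 1 to compound 3 (beyond the scatter) and a number 59 percentage points lower from compound 2 to compound 3 (beyond the scatter). Both are large and both point downward toward compound 3, so departing from that group in the other direction is expected to bring a number higher than compound 3. From the compounds shown here alone, the phenyl group itself is untested, so the size is uncertain. For compound 4 a modest rise is expected, a number 20 percentage points higher from compound 3 to compound 4 (beyond the scatter). The estimate for compound 4 is 125%, with a range from 85% to 170%.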

Compound 4, largest response reached (reported as efficacy), in percent of the reference or control that the assay uses: 158%
For compound 4 the middle estimate is 33 percentage points below the measured one; the range from low to high includes it.
By their numbers in this assay, from the lowest: compound 3; then compound 1; then compounds 4 and 2 (each within the scatter of the next).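

In this assay, the bare phenyl on the carbonyl carbon shows that this position needs no ring substituent to reach a large maximal response: replacing 2-chloro-6-methylphenyl gives a number 53 percentage points higher from compound 3 to compound 4 (beyond the scatter), a rise larger than either earlier step out of compound 3 in the opposite direction would have suggested on its own. The two chlorine-bearing rings both stand apart from phenyl, with the second case being a number 16 percentage points higher from compound 1 to compound 4 (beyond the scatter), whereas 2,5-dimethylphenyl goes against any general penalty for substitution, with a number 6 percentage points lower from compound 2 to compound 4 (within the scatter). No measurement shown gives a reason for these differences.

The compounds shown leave open how a phenyl carrying only a chlorine or only a methyl would stand, so the share of each substituent in compound 3 cannot be separated. They also leave open whether a methoxy group or a saturated cyclohexyl ring would be accepted on the carbonyl carbon.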